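This account rests on a few compounds, and the source may have more. Where it says the series, first, only, none or still open, it means among the compounds named here.

Measured so far in an ADME assay on HepG2 cells (Homo sapiens) for inhibition, with a stated time of 48 h; a lower number here means that less compound is needed, a higher number that more compound is needed for the effect:

- compound 1 `CCN(CC)C(=O)C(C)N1CCN(S(=O)(=O)c2ccc(C(C)(C)C)cc2)CC1`: > 40000 nM, a limit of the assay
- compound 2 `CC1CCN(C(=O)C(C)N2CCN(S(=O)(=O)c3ccc(C(C)(C)C)cc3)CC2)CC1`: > 40000 nM, a limit of the assay
- compound 3 `CC(C(=O)N1CCC(C)(C)CC1)N1CCN(S(=O)(=O)c2ccc(C(C)(C)C)cc2)CC1`: > 40000 nM, a limit of the assay

Compound 3 therefore stands at the limit in this assay, and it shares that position with both other compounds, as the limit of > 40000 nM in this assay, at which 3 of the 3 values shown sit, shows. None of the three steps among them can be read: a step that the two limits leave unreadable from compound 1 to compound 2, a step that the two limits leave unreadable from compound 1 to compound 3 and a step that the two limits leave unreadable from compound 2 to compound 3 all sit between two limits, so the size of any change on the carbonyl carbon, or on the saturated ring carbon, stays hidden.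

Compound 4 `CC(C(=O)N1CCc2ccccc21)N1CCN(S(=O)(=O)c2ccc(C(C)(C)C)cc2)CC1` differs from compound 3 by 2,3-dihydro-1H-indol-1-yl in place of 4,4-dimethylpiperidin-1-yl on a carbonyl carbon. Within the data shown here, the steps that bear on this change are those that also alter the group on the carbonyl carbon, from compound 1 to compound 2 and from compound 1 to compound 3, and neither gives a readable size. Among the measured compounds shown here, with three limits and no measured step to lean on, the most that can be expected is that compound 4 stays near the limit as well, with a step that the limit leaves unreadable from compound 3 to compound 4 expected to be no larger than the scatter. Compound 4 is accordingly estimated at 50000 nM, with a range from 15000 nM to 150000 nM.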

Compound 4, half-maximal effective concentration: > 40000 nM
Compound 4: no number, only a limit (the forecaster's own chance of this, stated with the estimate: 75%); the middle value is on the limit's open side.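

In this assay compound 4 gives > 40000 nM, a limit of the assay. Among these compounds, no step from compound 1, compound 2 or compound 3 to compound 4 can be read, and all four compounds stand at the same position: the limit of > 40000 nM in this assay, at which 4 of the 4 values shown sit. The compounds shown leave open whether any group on the carbonyl carbon changes the half-maximal effective concentration, and by how much.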